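The source may hold more compounds than are shown below. What is called first, only, known or untested is meant among the compounds shown, and "the series" means these compounds.

In a functional assay on A549 cells (Homo sapiens) for cytotoxicity, read by MTT assay, with a stated time of 72 h (on this read-out higher numbers stand for weaker inhibition and lower numbers for stronger inhibition), compound 1 `CC1(C)OCC(Cn2cc(Cn3c4c(c5ccccc53)C(=O)c3c[n+]([O-])c5ccccc5c3C4=O)nn2)O1` gives 80 nM and compound 2 `CN1CCN(CCCCn2c3c(c4ccccc42)C(=O)c2c[n+]([O-])c4ccccc4c2C3=O)CC1` gives 90 nM. Compound 2 therefore stands level with compound 1, because 80 nM and the value of compound 2 at 90 nM lie within the usual scatter of repeated measurements. The next compound to be tested is compound 3 `O=C1c2c[n+]([O-])c3ccccc3c2C(=O)c2c1c1ccccc1n2CCN1CCCCC1`, and it differs from compound 2 as follows: piperidin-1-yl in place of 2-(4-methylpiperazin-1-yl)ethyl on a saturated chain carbon, two bonds along the chain from an aromatic nitrogen. In words, piperidin-1-yl takes the place of 2-(4-methylpiperazin-1-yl)ethyl on a saturated chain carbon, two bonds along the chain from an aromatic nitrogen. Within the data shown here, no measured pair shows this change on its own, so the evidence is thin. Still, compound 1 and compound 2 carry very different groups on the shared core and show no gap beyond the scatter. No step beyond the scatter is therefore expected, and the estimated change is a 1.1-fold higher number from compound 2 to compound 3 (0.05 log units; within the scatter). For compound 3 the expected value is 100 nM, with an estimated range of 40 nM to 250 nM.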

Compound 3, half-maximal inhibitory concentration: 1080 nM
Beside the measured number, compound 3's estimate is 11-fold (1.03 log units) below it, and the stated range ends below it.
By their numbers in this assay, from the lowest: compounds 1 and 2 (each within the scatter of the next); then compound 3.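

In this assay, replacing 2-(4-methylpiperazin-1-yl)ethyl with piperidin-1-yl on a saturated chain carbon, two bonds along the chain from an aromatic nitrogen, gives a 12-fold higher number from compound 2 to compound 3 (1.08 log units; beyond the scatter). Among these compounds, this is the first step beyond the scatter, and it shows that a change at this place can weaken the read-out markedly while the shared core stays the same. Nothing shown here explains the step.

Read one bond further out, the same difference is 4-(4-methylpiperazin-1-yl)butyl to 2-(piperidin-1-yl)ethyl, so a shorter chain and a different ring arrive together and this one pair cannot separate them. Open questions are how piperidin-1-yl behaves on a butyl chain, how 4-methylpiperazin-1-yl behaves on an ethyl chain, and where a morpholin-4-yl ring would fall on either chain.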